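A few compounds are considered here, and "the series" means these few. Any claim that something is new, unique, unknown or untested is made for them only; others in the source may bear on it.

Working notes on the series. Three compounds have numbers in a functional assay on Ramos cells (Homo sapiens) for antiproliferative activity, read by CCK-8 assay, with a stated time of 72 h; a lower number here means a stronger inhibitor, a higher number a weaker inhibitor. Within the data shown here, compound 1 `CCOC(=O)c1sc(-c2cccc(NC(=O)c3ccc(F)c(Cl)c3)c2)nc1Nc1ccc(N2CCN(C)CC2)cc1` gives 29200 nM; compound 2 `CN1CCN(c2ccc(Nc3nc(-c4cccc(NC(=O)c5ccc(F)c(Cl)c5)c4)sc3C(=O)O)cc2)CC1` gives 5600 nM; compound 3 `CN1CCN(c2ccc(Nc3nc(-c4cccc(NC(=O)c5ccccc5)c4)sc3C(N)=O)cc2)CC1` gives 1760 nM, the lowest of the three, sitting a 5.2-fold lower number from compound 1 to compound 2 (0.72 log units; beyond the scatter) aside as the one measured step, which concerns the acid end of the core and not the aryl amide. Compound 3 differs from compound 2 in two places at once, so the gap between them cannot be split into parts.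

Compound 4 `CN1CCN(c2ccc(Nc3nc(-c4cccc(NC(=O)c5ccc(F)c(Cl)c5)c4)sc3C(N)=O)cc2)CC1` is the next member, reached from compound 3 by 3-chloro-4-fluorophenyl in place of phenyl on a carbonyl carbon. Among the measured compounds shown here, no measured step in this assay changes this aryl group alone: compounds 1 and 2 carry the 3-chloro-4-fluorophenyl already, compound 3 carries phenyl, and their other differences cloud any reading. The expectation therefore rests on compound 3 alone, and the step of a 1.2-fold lower number from compound 3 to compound 4 (0.07 log units; within the scatter) is expected to stay within the usual scatter. Compound 4 is estimated at 1500 nM, with a range from 500 nM to 5000 nM.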

Compound 4, half-maximal inhibitory concentration: 4830 nM
Estimate against measurement, compound 4: 3.2-fold (0.51 log units) below; measured number inside the range.
By their numbers in this assay, from the lowest: compound 3; then compounds 4 and 2 (each within the scatter of the next); then compound 1.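

In this assay, the aryl group on the amide carbonyl can now be read alone: a 2.7-fold higher number from compound 3 to compound 4 (0.44 log units; beyond the scatter), so 3-chloro-4-fluorophenyl in place of phenyl on a carbonyl carbon gives the higher number. With 3-chloro-4-fluorophenyl held fixed, the other carbonyl group can also be read: the ethyl ester stands apart, with a 6.0-fold lower number from compound 1 to compound 4 (0.78 log units; beyond the scatter) for amino in place of ethoxy, whereas a 1.2-fold lower number from compound 2 to compound 4 (0.06 log units; within the scatter) leaves amino and hydroxy unseparated. Nothing measured here gives a cause for these steps.

Still open, on these data alone, is whether the step from phenyl belongs to the chlorine, the fluorine or both, and whether it holds with the carboxylic acid or ethyl ester on the core. A methoxy group on the phenyl, or methylamino in place of amino on the core carbonyl, would probe each position further.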